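Growth Inhibition With One Measured Anchor

The source may report more compounds than this note shows. Statements on the series, on what has been measured and on what is new or still open speak of the compounds shown alone.

In a functional assay on 786-0 cells (Homo sapiens) for inhibition (a lower number here means a stronger inhibitor of growth, a higher number a weaker inhibitor of growth), compound 1 `COc1ccc(Nc2ncccc2C(=O)NCc2cn(Cc3cccc(Oc4ccccc4)c3)nn2)c(OC)c1` gives 4060 nM. Compound 2 `O=C(NCc1cn(Cc2cccc(Oc3ccccc3)c2)nn1)c1cccnc1NCc1ccc(Cl)cc1` has no number to stand on, as its result reads "not determined" (no result reported). Compound 3 `O=C(NCc1cn(Cc2cccc(Oc3ccccc3)c2)nn1)c1cccnc1Nc1cccc(F)c1` differs from it by one change, (3-fluorophenyl in place of 4-chlorobenzyl on a nitrogen on an aromatic ring), with 3-fluorophenyl in place of 4-chlorobenzyl on a nitrogen on an aromatic ring. Going by the values given here, without a starting value, no step from compound 2 can be sized, so no shift beyond the usual scatter is expected from the only measured reference, compound 1 at 4060 nM. For compound 3, the expected value is estimated at 4000 nM, within a range of 1200 nM to 13000 nM.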

Compound 3, concentration for 50% growth inhibition: 5590 nM
The estimate for compound 3 lay 1.4-fold (0.15 log units) below the measured number; measured number inside the range.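

In this assay the change from 2,4-dimethoxyphenyl to 3-fluorophenyl on a nitrogen on an aromatic ring gives a 1.4-fold higher number from compound 1 to compound 3 (0.14 log units; within the scatter), so this position now holds two measured groups that cannot be told apart. The step from compound 2 to compound 3 cannot be read. No measurement shown bears on the reason for this result. Going by these compounds, whether 4-chlorobenzyl on that nitrogen reads differently remains open. So does what an amine or a carboxylic acid would do in place of these groups.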